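This account rests on a few compounds, and the source may have more. Where it says the series, first, only, none or still open, it means among the compounds named here.

Compound 1 `CCCCCCC[C@@H](CCO)n1cnc2c(Cl)ncnc21` gives 3820 nM in a functional assay on SW480 cells (Homo sapiens) for antiproliferative activity, read by MTT assay, with a stated time of 48 h (on this read-out higher numbers stand for weaker inhibition and lower numbers for stronger inhibition), the higher of the two numbers, with compound 2 `CCCCCCC[C@H](CCO)n1cnc2c(Cl)ncnc21` nearest at 2930 nM. Those two differ only in configuration as drawn, and the step of a 1.3-fold lower number from compound 1 to compound 2 (0.12 log units; within the scatter) shows that the change of configuration alone does not move the number beyond the scatter. Compound 3 `CCCCCCCCC[C@@H](CCO)n1cnc2c(Cl)ncnc21` carries a different change from compound 1: ethyl in place of hydrogen on a saturated chain carbon, eight bonds along the chain from an aromatic nitrogen. Within the data shown here, no measured step bears on a lengthened chain, so compound 3 is expected to stay near compound 1, with a step of a 1.3-fold lower number from compound 1 to compound 3 (0.10 log units; within the scatter) and an estimated value of 3000 nM, between 1000 nM and 10000 nM.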

Compound 3, half-maximal inhibitory concentration: 3620 nM
Compound 3: the middle estimate sits 1.2-fold (0.08 log units) below what was measured; the range from low to high includes it.
By their numbers in this assay, from the lowest: compounds 2, 3 and 1 (each within the scatter of the next).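

Among these compounds, with ethyl in place of hydrogen on this saturated chain carbon, this assay records a 1.1-fold lower number from compound 1 to compound 3 (0.02 log units; within the scatter) and so gives the first reading on chain length at this position: the added ethyl leaves the number within the scatter. Thus both the change of configuration and this lengthening of the chain leave antiproliferative activity unresolved from that of compound 1. No evidence given here bears on why the lengthened chain leaves the number within the scatter. Still open, on these data alone, is whether a longer chain, or an amine or a carboxylic acid on this same carbon, would move the number beyond the scatter.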